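Replacing Hydroxy with an Ether Chain on the Shared Core

The compounds below may be only part of what the source reports. "The series", "measured", "known", "first", "only" and "open" are said of these compounds alone.

In an ADME assay on CEM-SS cells (Homo sapiens) for cytotoxicity, read by XTT assay (a lower number here means that less compound is tolerated, a higher number that more compound is tolerated), compound 2 `CN(O)C(=O)c1cc2c(CO)cn(Cc3ccc(F)cc3)c2cn1` gives only a limit, > 266000 nM. Compound 1 `CN1CCN(Cc2cn(Cc3ccc(F)cc3)c3cnc(C(=O)N(C)O)cc23)CC1` also gives only a limit, > 224000 nM. The comparison between these two is a step that the two limits leave unreadable from compound 1 to compound 2. Compound 3 `CCOCCOCc1cn(Cc2ccc(F)cc2)c2cnc(C(=O)N(C)O)cc12` gives a true number, 81000 nM.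

Compound 4 `COCCOCCCc1cn(Cc2ccc(F)cc2)c2cnc(C(=O)N(C)O)cc12` departs from compound 2 by one change: 2-(2-methoxyethoxy)ethyl in place of hydroxy on a saturated chain carbon bound to an aromatic carbon. A 2-(2-methoxyethoxy)ethyl group stands in place of hydroxy on a saturated chain carbon bound to an aromatic carbon, so that hydroxymethyl becomes 3-(2-methoxyethoxy)propyl.

For the measured compounds named here, the nearest precedent is compound 3, the only measured compound with an ether chain at this place. Its two steps are an at least 3.2-fold lower number from compound 2 to compound 3 (0.51 log units; beyond the scatter) and an at least 2.7-fold lower number from compound 1 to compound 3 (0.44 log units; beyond the scatter). Both start from limits, so each gives a minimum size and not an exact one. The chain of compound 4 is not the same as that of compound 3, but the step to compound 3 in this assay suggests the same direction, with a size of the same modest order. The expected change is an at least 3.3-fold lower number from compound 2 to compound 4 (0.52 log units; beyond the scatter), toward a lower number and beyond the scatter. Compound 4 is estimated at 80000 nM, with an expected range of 35000 nM to 200000 nM.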

Compound 4, half-maximal cytotoxic concentration: > 10000 nM
Compound 4 gave a limit, no number (the forecaster's own chance of this, stated with the estimate: 15%); the middle value is on the limit's open side.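

In this assay compound 4 gives only a limit, > 10000 nM. The steps to compound 4 from compound 1, compound 2 and compound 3 therefore cannot be read. The compounds shown leave open whether the 3-(2-methoxyethoxy)propyl chain of compound 4 gives a lower number than the hydroxymethyl of compound 2, as the ether chain of compound 3 does.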